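The source may hold more compounds than are shown below. What is called first, only, known or untested is meant among the compounds shown, and "the series" means these compounds.

Working notes on the series.

The read-out throughout is a functional assay on MCF7 cells (Homo sapiens) for cytotoxicity, read by MTT assay, with a stated time of 72 h; on this read-out higher numbers stand for lower toxicity in this test and lower numbers for higher toxicity in this test. Compound 1 `CS/C(=N\C(=O)c1csc([N+](=O)[O-])c1)NC(=O)c1csc([N+](=O)[O-])c1` carries two nitro-substituted thiophene carbonyl arms on a methylsulfanyl-bearing core; in this assay compound 1 gives > 100000 nM, which is a limit of the assay and not a number. Compound 2 `CS/C(=N\C(=O)c1ccno1)NC(=O)c1ccno1` is the isoxazole analogue; in this assay compound 2 gives > 100000 nM, again a limit. How the core of compound 1 and that of compound 2 differ is not broken down here.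

Compound 3 `O=C(/N=C(/NC(=O)c1ccno1)[Se]Cc1ccccc1)c1ccno1` is obtained from compound 2 by a group of 8 heavy atoms (7 carbon, 1 selenium; one six-membered aromatic ring of carbon only) in place of a group of 2 heavy atoms (1 carbon, 1 sulfur; no ring), on a carbon with a double bond to nitrogen. In this assay compound 3 gives > 100000 nM, also a limit. The resulting step that the two limits leave unreadable from compound 2 to compound 3 is therefore not readable, because of the limit of > 100000 nM in this assay, at which 3 of the 3 values shown sit.

Compound 4 `O=C(/N=C(/NC(=O)c1csc([N+](=O)[O-])c1)[Se]Cc1ccccc1)c1csc([N+](=O)[O-])c1` arises from compound 1 by a group of 8 heavy atoms (7 carbon, 1 selenium; one six-membered aromatic ring of carbon only) in place of a group of 2 heavy atoms (1 carbon, 1 sulfur; no ring), on a carbon with a double bond to nitrogen, the same change as from compound 2 to compound 3, at a place described in identical words. Since the step that the two limits leave unreadable from compound 2 to compound 3 cannot be sized, the expectation for compound 4 rests on (the limit of > 100000 nM in this assay, at which 3 of the 3 values shown sit), and a step that the limit leaves unreadable from compound 1 to compound 4 of essentially nil is expected. Compound 4 is estimated at 150000 nM, most likely reported as a limit, with a range from 40000 nM to 600000 nM.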

Compound 4, concentration lethal to 50% of the cells: 83800 nM
Beside the measured number, compound 4's estimate is 1.8-fold (0.25 log units) above it, and the stated range covers the measured number.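

On the core of compound 1, in this assay, the change gives an at least 1.1-fold lower number from compound 1 to compound 4 (0.07 log units; that floor lies within the scatter), so the pair supplies only a floor and does not separate the two compounds. The matching step on the core of compound 2 cannot be read, and no size can be carried from one core to the other, because most of the values are limits: the limit of > 100000 nM in this assay, at which 3 of the 4 values shown sit. Compound 4 alone carries a measured number, which shows that a readable value can occur with this change on this core, but not that the change acts differently on the two cores, nor that it has any effect at all.

The compounds shown leave open whether the selenium or the six-membered aromatic ring of the entering group matters, as the two always enter together. They also leave open whether an amine or a longer carbon chain in place of methylsulfanyl, on a carbon with a double bond to nitrogen, would give a clearly lower number on either core.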